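Adding a chloro group to the thiophene of compound 2

A few compounds are considered here, and "the series" means these few. Any claim that something is new, unique, unknown or untested is made for them only; others in the source may bear on it.

In a functional assay on the whole organism (strain Zucker) for inhibition, with Rattus norvegicus as the target, with a stated time of 4 h, at a dose of 10 mg/kg by the oral route (on this read-out lower numbers stand for less inhibition and higher numbers for more inhibition at the one dose given (going by the name of the read-out)), two compounds have been measured. Compound 1 `O=C(NN1CCOCC1)C1=NN(c2ccc(Cl)cc2Cl)C(c2ccccc2)C1` gives 31.9%, and compound 2 `Clc1ccc(N2N=C(CNN3CCOCC3)CC2c2cccs2)c(Cl)c1` gives 3%, the lowest of the two numbers and a gap from compound 1 that lies beyond the usual scatter of this kind of measurement. Going by the values given here, no single-point step between measured compounds is available, so the pair shows only that the two numbers differ widely.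

Compound 3 `Clc1ccc(N2N=C(CNN3CCOCC3)CC2c2ccc(Cl)s2)c(Cl)c1` has not yet been measured. It differs from compound 2 by chloro in place of hydrogen on an aromatic carbon, the same difference read one bond further out being thiophen-2-yl to 5-chlorothiophen-2-yl. Nothing measured here speaks to this change, so the step from compound 2 to compound 3 in this assay is expected to be small, a number 5 percentage points higher from compound 2 to compound 3 (within the scatter), and not beyond the scatter. Compound 3 is therefore estimated at 8%, within a range from 0% to 25%.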

Compound 3, a percentage reported as inhibition, in the whole organism at one dose (the size of the read-out at that dose, not a potency): 16.7%
The estimate for compound 3 lay 8.7 percentage points below the measured number; low and high end bracket the measured number.
By their numbers in this assay, from the lowest: compound 2; then compound 3; then compound 1.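

Going by these compounds alone, the change from thiophen-2-yl to 5-chlorothiophen-2-yl is the first single-place change that can be read in this assay, and it gives a number 13.7 percentage points higher from compound 2 to compound 3 (beyond the scatter). This makes the aromatic carbon next to the ring sulfur, two ring bonds from the ring atom that bears a large group, a place where one chlorine atom changes the read-out by a modest amount at this single dose. Nothing in the data bears on what lies behind this step.

The compounds shown leave open whether another group on this carbon, such as bromo, methyl or nitrile, would give a step of similar size. They also leave open whether the step would hold at another dose or another time.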